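This account rests on a few compounds, and the source may have more. Where it says the series, first, only, none or still open, it means among the compounds named here.

Of the compounds shown here, three built on a shared core have been tested in a functional assay on OVCAR-3 cells (Homo sapiens) for antiproliferative activity, read by MTT assay, with a stated time of 24 h; on this read-out higher numbers stand for weaker inhibition and lower numbers for stronger inhibition. Compound 1 `O=C(NNc1cccc(Cl)c1)c1ccc(NS(=O)(=O)c2cnc(O)nc2O)cc1` gives 8410 nM in this assay. Compound 2 `O=C(NNc1ccc(F)cc1)c1cccc(NS(=O)(=O)c2cnc(O)nc2O)c1` reads > 20000 nM, which is a limit of the assay and not a number. Compound 3 `Cc1cccc(NNC(=O)c2ccccc2NS(=O)(=O)c2cnc(O)nc2O)c1` reads > 20000 nM, which is also a limit. Compound 2 thus stands at the limit of > 20000 nM in this assay, at which 2 of the 3 values shown sit. Compound 4 `O=C(NNC(=O)c1ccccc1Cl)c1cccc(NS(=O)(=O)c2cnc(O)nc2O)c1` carries (2-chlorophenyl)carbonyl in place of 4-fluorophenyl on an amine nitrogen. Among the measured compounds shown here, no measured step shows the effect of this change. The expected at least 1.2-fold lower number from compound 2 to compound 4 (0.09 log units; that floor lies within the scatter) in this assay is therefore none beyond the scatter. Compound 4 is estimated at 16000 nM, with an expected range of 6000 nM to 30000 nM.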

Compound 4, half-maximal inhibitory concentration: 7300 nM
Compound 4: middle estimate off by 2.2-fold (0.34 log units), on the high side; the range from low to high includes it.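

In this assay, putting (2-chlorophenyl)carbonyl in place of 4-fluorophenyl on an amine nitrogen gives an at least 2.7-fold lower number from compound 2 to compound 4 (0.43 log units; beyond the scatter). Among the compounds shown here, this is the first readable step, and it shows that the group on this nitrogen can move the read-out, which the earlier compounds, linked by no step, could not show. The size of the step is only a floor, as the reading of compound 2 is a limit and not a number: the limit of > 20000 nM in this assay, at which 2 of the 4 values shown sit.

The compounds shown leave open whether the carbonyl or the chlorine accounts for the step. They also leave open how an acetyl group or a longer alkyl chain on this nitrogen would read.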